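The compounds below may be only part of what the source reports. "The series", "measured", "known", "first", "only" and "open" are said of these compounds alone.

In a functional assay on HT-1080 cells (Homo sapiens) for cytotoxicity, read by MTT assay, with a stated time of 72 h (on this read-out higher numbers stand for weaker inhibition and lower numbers for stronger inhibition), compound 1 `COc1ccccc1/C=C1\CCC/C(=C\c2cccc(OC)c2OC)C1=O` gives 14100 nM. Compound 2 `COc1cccc(/C=C2\CCC/C(=C\c3cccc(OC)c3OC)C2=O)c1` gives 9900 nM, and compound 3 `COc1cccc(/C=C2\CCC/C(=C\c3ccc(Cl)c(Cl)c3)C2=O)c1OC` gives 10800 nM. Compound 1 therefore stands level with both, since all three numbers lie within the scatter of one another.

Compound 4 `COc1ccc(/C=C2\CCC/C(=C\c3cccc(OC)c3OC)C2=O)c(OC)c1` differs from compound 1 by one change: methoxy in place of hydrogen on an aromatic carbon. Among the compounds with values here, no measured compound carries this exact change, so the evidence is indirect. Two measured changes on the same ring bear on it: one gave a 1.4-fold lower number from compound 1 to compound 2 (0.15 log units; within the scatter), and the other gave a 1.3-fold lower number from compound 1 to compound 3 (0.12 log units; within the scatter). The remaining comparison gave a 1.1-fold higher number from compound 2 to compound 3 (0.04 log units; within the scatter). All of these steps are small, and none leaves the scatter, so this ring has so far tolerated replacement without a clear shift in this assay. By that reading, no step beyond the scatter is expected here, and the expected step is a 1.2-fold lower number from compound 1 to compound 4 (0.07 log units; within the scatter). Compound 4 is estimated at 12000 nM, with an expected range of 6000 nM to 24000 nM.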

Compound 4, half-maximal inhibitory concentration: > 20000 nM
Compound 4: only a limit was reported; the forecaster's own chance of this, stated with the estimate: 10%; middle value at least 1.6-fold (0.22 log units) away from the limit.
By their numbers in this assay, from the lowest: compounds 2, 3 and 1 (each within the scatter of the next). At a limit, above all of these: compound 4.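

In this assay compound 4 gives no number, only a limit: the limit of > 20000 nM in this assay, at which 1 of the 4 values shown sits.

Methoxy in place of hydrogen on an aromatic carbon, meta to a methoxy group and para to a large group, gives an at least 1.4-fold higher number from compound 1 to compound 4 (0.15 log units; that floor lies within the scatter). Unlike the earlier changes on this ring, whose full steps all stay within the scatter, this step has only a floor, so the true size of the change at this position is unknown and may or may not exceed the scatter.

The compounds shown leave open whether any shift at this position belongs to methoxy itself or would also appear with a fluorine, a hydroxyl or an amine in the same place. They also leave open whether a methoxy at this position would read the same with a different group on the other ring of the shared core.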